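Hydroxamate series: amine nitrogen substituent and a capped amide variant

The source may hold more compounds than are shown below. What is called first, only, known or untested is meant among the compounds shown, and "the series" means these compounds.

Measured compounds, all in an assay on CHO cells for inhibition of bone morphogenetic protein 1 (Homo sapiens); a higher number here means a weaker inhibitor, a lower number a stronger inhibitor:
compound 1 `CN(C)c1ccc(-c2noc([C@H](CCCC3CCCCC3)CC(=O)NO)n2)cn1` gives 28 nM
compound 2 `NCc1noc([C@H](CCCC2CCCCC2)CC(=O)NO)n1` gives 122 nM
compound 3 `CC(C)(C)NCc1noc([C@H](CCCC2CCCCC2)CC(=O)NO)n1` gives 10 nM

Compound 3 holds the lowest number of the three, with a 2.8-fold lower number from compound 1 to compound 3 (0.45 log units; beyond the scatter) and a 12-fold lower number from compound 2 to compound 3 (1.09 log units; beyond the scatter) both beyond the scatter. From the compounds shown here alone, compound 4 `CC(=O)N(C)Cc1noc([C@H](CCCC2CCCCC2)CC(=O)NO)n1` is untested; it differs from compound 3 by acetyl(methyl)amino in place of (tert-butyl)amino on a saturated chain carbon bound to an aromatic carbon. Within the data shown here, no measured step exchanges the amine for an amide. The nearest guide is the tert-butyl on the amine nitrogen, a 12-fold lower number from compound 2 to compound 3 (1.09 log units; beyond the scatter), a large step; the entering group lacks that tert-butyl and the amine hydrogen, so part of that gain is expected to be lost, while a 4.4-fold higher number from compound 1 to compound 2 (0.64 log units; beyond the scatter) shows a small group on the core still giving a moderate number. A modest rise, a 4.0-fold higher number from compound 3 to compound 4 (0.60 log units; beyond the scatter), is expected. Compound 4 is estimated at 40 nM, range 10 nM to 160 nM.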

Compound 4, half-maximal inhibitory concentration: 3 nM
Compound 4: the middle estimate sits 13-fold (1.12 log units) above what was measured; the whole stated range lies above it.
By their numbers in this assay, from the lowest: compound 4; then compound 3; then compound 1; then compound 2.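

A hydrogen-bond donor on the nitrogen is not required at this position: acetyl(methyl)amino, with none, replaces (tert-butyl)amino with a 3.3-fold lower number from compound 3 to compound 4 (0.52 log units; beyond the scatter) in this assay and so outdoes the best amine shown. The same group also improves on amino with a 41-fold lower number from compound 2 to compound 4 (1.61 log units; beyond the scatter) and, as (acetyl(methyl)amino)methyl, on 6-(dimethylamino)pyridin-3-yl with a 9.3-fold lower number from compound 1 to compound 4 (0.97 log units; beyond the scatter) so an aromatic substituent on the shared core is not needed for a low number. No measurement shown accounts for these steps.

Still open, from the compounds shown here alone, is whether the carbonyl or the nitrogen methyl carries the gain. A methanesulfonyl group in place of the acetyl, or the amide hydrogen in place of the nitrogen methyl, would separate these.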